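Replacing the ring group with methoxy on the side chain

The source may report more compounds than this note shows. Statements on the series, on what has been measured and on what is new or still open speak of the compounds shown alone.

- compound 1 `O=C1O[C@@H](CO)CN1c1ccc(-n2cc(-c3ccccn3)cn2)c(F)c1`: > 400 ug/mL (a limit)
- compound 2 `O=C1CSC(=O)N1C[C@H]1CN(c2ccc(-n3cc(-c4ccccn4)cn3)c(F)c2)C(=O)O1`: 283 ug/mL

Among the measured compounds shown here, in an ADME assay on HEK293-A cells (Homo sapiens) for cytotoxicity, read by MTT assay, with a stated time of 48 h (on this read-out higher numbers stand for weaker inhibition and lower numbers for stronger inhibition), compound 2 holds the only exact number, 283 ug/mL. Compound 1 reaches only a limit of the assay, as the limit of > 400 ug/mL in this assay, at which 1 of the 2 values shown sits, records. Compound 3 `COC[C@H]1CN(c2ccc(-n3cc(-c4ccccn4)cn3)c(F)c2)C(=O)O1` differs from compound 2 by one change: methoxy in place of 2,4-dioxo-1,3-thiazolidin-3-yl on a saturated chain carbon bound to a saturated ring carbon. For the measured compounds named here, one measured step bears on it: an at least 1.4-fold lower number from compound 1 to compound 2 (0.15 log units; that floor lies within the scatter), where the same ring group took the place of hydroxy. No change beyond the scatter is therefore expected in this assay, and any drift should be towards a higher number. The estimated step is a 1.2-fold higher number from compound 2 to compound 3 (0.08 log units; within the scatter). For compound 3 the expected value is 340 ug/mL, with an estimated range of 160 ug/mL to 700 ug/mL.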

Compound 3, half-maximal inhibitory concentration: > 400 ug/mL
Compound 3 gave a limit, no number; the forecaster's own chance of this, stated with the estimate: 35%; middle value at least 1.1-fold (0.07 log units) away from the limit.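

Placing methoxy on a saturated chain carbon bound to a saturated ring carbon, where compound 2 carries 2,4-dioxo-1,3-thiazolidin-3-yl, gives in this assay an at least 1.4-fold higher number from compound 2 to compound 3 (0.15 log units; that floor lies within the scatter). Among the compounds shown here, compound 3, like compound 1, ends at a limit, so compound 2 remains the only one with an exact number: the limit of > 400 ug/mL in this assay, at which 2 of the 3 values shown sit. The step between compound 1 and compound 3 cannot be read.

Going by these compounds, how far compound 1 and compound 3 really lie from compound 2 stays open. So does whether an amine or a carboxylic acid at this place would give an exact number.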